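Trifluoromethyl for chloro in a second core, expected cytotoxicity

A few compounds are considered here, and "the series" means these few. Any claim that something is new, unique, unknown or untested is made for them only; others in the source may bear on it.

Compound 1 `O=C1C(=O)N(CN2CCN(c3ccnc4cc(Cl)ccc34)CC2)c2cccc(Br)c21` and compound 2 `O=C1C(=O)N(CN2CCN(c3ccnc4cc(C(F)(F)F)ccc34)CC2)c2cccc(Br)c21` share one core and differ only in the group on the fused aromatic ring. In an ADME assay on 184B5 cells (Homo sapiens) for cytotoxicity, read by sulforhodamine B assay, with a stated time of 48 h (on this read-out lower numbers stand for stronger inhibition of growth and higher numbers for weaker inhibition of growth), compound 1 gives 49000 nM, and compound 2 gives 49700 nM. The change between them is trifluoromethyl in place of chloro on an aromatic carbon, and the step it made, a 1.0-fold higher number from compound 1 to compound 2 (0.01 log units; within the scatter), lies within the scatter of the measurement.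

Compound 3 `NC(=S)N/N=C1/C(=O)N(CN2CCN(c3ccnc4cc(Cl)ccc34)CC2)c2cc(Cl)ccc21` carries a different core; how the core of compound 3 differs from the core of compound 1 is not broken down here. In this assay compound 3 gives 41300 nM. Its value, set beside those of compound 1 and compound 2, falls within the scatter of both, so no order among the three is claimed.

Compound 4 `NC(=S)N/N=C1/C(=O)N(CN2CCN(c3ccnc4cc(C(F)(F)F)ccc34)CC2)c2cc(Cl)ccc21` is not yet measured. It stands to compound 3 as compound 2 stands to compound 1: the change is trifluoromethyl in place of chloro on an aromatic carbon, and the place lines of the two changes agree word for word, so it is the same change on a second core.

Among the compounds with values here, the one measured instance of this change, from compound 1 to compound 2, made a step within the scatter. With nothing else to go on, the step from compound 3 to compound 4 is expected to be of similar size, a 1.0-fold higher number from compound 3 to compound 4 (0.01 log units; within the scatter), because the earlier step was a 1.0-fold higher number from compound 1 to compound 2 (0.01 log units; within the scatter). Compound 4 is therefore estimated at 42000 nM in this assay, with an expected span from 24000 nM to 75000 nM.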

Compound 4, concentration for 50% growth inhibition: 20100 nM
The estimate for compound 4 lay 2.1-fold (0.32 log units) above the measured number, outside the stated range (below it).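

In this assay, trifluoromethyl in place of chloro on the core of compound 3 gives a 2.1-fold lower number from compound 3 to compound 4 (0.31 log units; beyond the scatter), so on this core the change produces a step beyond the scatter, whereas on the core of compound 1 it produced none. That contrast is not firm enough to separate the two cores, as the two steps do not differ by more than two such steps can scatter: the same change on two cores in this assay, a 1.0-fold higher number (0.01 log units; within the scatter) from compound 1 to compound 2 and a 2.1-fold lower number (0.31 log units; beyond the scatter) from compound 3 to compound 4, 2.1-fold (0.32 log units) apart, within the scatter of two such steps. The pairs therefore fit a single modest effect carried across both cores as well as an effect present on only one of them, and they neither show that the change transfers reliably nor that the core alters it.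

As far as these compounds go, whether the lower number on the core of compound 3 holds for other groups at the same aromatic carbon, such as fluoro, methyl, methoxy or nitrile, remains open. Also open, from the compounds shown here alone, is which of the several differences between the two cores would matter if the steps did prove to differ, and whether any group could carry the numbers in this assay well away from the narrow range seen so far.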